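Hydroxy for cyano on the aryl ring of compound 3

A few compounds are considered here, and "the series" means these few. Any claim that something is new, unique, unknown or untested is made for them only; others in the source may bear on it.

Compound 3 `C=CC[C@H]1C[C@]2([C@@H](C)Cc3cc(C#N)c(OC)cc3F)OCOC2=CC1=O` gives 37 nM in a functional assay on M14 cells (Homo sapiens) for antiproliferative activity, with a stated time of 72 h (a higher number here means a weaker inhibitor, a lower number a stronger inhibitor), second highest of the three numbers: compound 2 `C=CC[C@H]1C[C@]2(C(C)Cc3ccc(OC)c(OC(C)=O)c3)OCOC2=CC1=O` gives 16 nM, and compound 1 `C=CC[C@H]1C[C@]2([C@@H](C)Cc3ccc(OC)c(C#N)c3)OCOC2=CC1=O` gives 180 nM. For the measured compounds named here, the only single-point step, a 4.9-fold lower number from compound 1 to compound 3 (0.69 log units; beyond the scatter), concerns a fluoro and does not bear on the change to compound 4 `C=CC[C@H]1C[C@]2([C@@H](C)Cc3cc(O)c(OC)cc3F)OCOC2=CC1=O`, which is hydroxy in place of cyano on an aromatic carbon. Going by the values given here, compounds 1 and 2 differ at the corresponding position but also elsewhere, so their values show only that an oxygen-linked group there is compatible with a strong result. Compound 4 is therefore expected to stay near or somewhat below compound 3, a step of a 1.5-fold lower number from compound 3 to compound 4 (0.17 log units; within the scatter). The estimate for compound 4 is 25 nM, within 8 nM to 80 nM.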

Compound 4, half-maximal inhibitory concentration: 9 nM
Compound 4: middle estimate off by 2.8-fold (0.44 log units), on the high side, and the stated range covers the measured number.
By their numbers in this assay, from the lowest: compounds 4 and 2 (each within the scatter of the next); then compound 3; then compound 1.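

In this assay, replacing cyano with hydroxy on this aromatic carbon, ortho to a methoxy group and para to a fluoro group, gives a 4.1-fold lower number from compound 3 to compound 4 (0.61 log units; beyond the scatter). For the compounds shown here, this is the first reading at this position in which nothing else changes, and it shows that the cyano group is not needed there for a strong result. Nothing available explains the gain. On these data alone, how an amine or a carboxylic acid on this carbon would compare remains open. So does whether the step would hold without the fluoro group.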